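The compounds below may be only part of what the source reports. "The series", "measured", "known", "first", "only" and "open" are said of these compounds alone.

Compound 1 `CCCCOC(=O)NS(=O)(=O)c1sc(CC(C)C)cc1-c1ccc(CN2CCN(C)C2=O)cc1`: 16.5 nM
Compound 2 `CCCCOC(=O)NS(=O)(=O)c1sc(CC(C)C)cc1-c1ccc(C(=O)c2ccnn2C)cc1`: 3.4 nM
Compound 3 `CCCCOC(=O)NS(=O)(=O)c1sc(CC(C)C)cc1-c1ccc(CN2C(=O)N(C)C(C)(C)C2=O)cc1`: 3.6 nM

These three compounds share one core and differ only in the group carried on one aromatic carbon. In an assay on membranes from uterus for displacement of a labelled ligand from Angiotensin type II receptor (Sus scrofa), with a stated time of 1.5 h (on this read-out higher numbers stand for weaker inhibition and lower numbers for stronger inhibition), compound 3 stands second highest of the three numbers; its nearest neighbour is shown by a 1.1-fold higher number from compound 2 to compound 3 (0.02 log units; within the scatter) and its furthest by a 4.6-fold lower number from compound 1 to compound 3 (0.66 log units; beyond the scatter).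

Compound 4 `CCCCOC(=O)NS(=O)(=O)c1sc(CC(C)C)cc1-c1ccc(C(=O)c2nccs2)cc1` has not yet been measured. It differs from compound 3 in one place: a group of 7 heavy atoms (4 carbon, 1 nitrogen, 1 oxygen, 1 sulfur; one five-membered aromatic ring with 2 hetero atoms) in place of a group of 11 heavy atoms (7 carbon, 2 nitrogen, 2 oxygen; one five-membered non-aromatic ring with 2 hetero atoms), on an aromatic carbon. Among the measured compounds shown here, two measured steps bear on this. a 1.1-fold higher number from compound 2 to compound 3 (0.02 log units; within the scatter) sets a five-membered aromatic ring linked through a carbonyl against the non-aromatic ring and lies within the scatter. a 4.9-fold lower number from compound 1 to compound 2 (0.69 log units; beyond the scatter) shows that a carbonyl-linked aromatic ring gives a lower number. Since the entering group is again an aromatic ring on a carbonyl, no step beyond the scatter is expected: a 1.0-fold lower number from compound 3 to compound 4 (0.01 log units; within the scatter). Compound 4 is therefore estimated at 3.5 nM, within 1.5 nM to 8 nM.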

Compound 4, inhibition constant: 18.6 nM
Compound 4: middle estimate off by 5.3-fold (0.73 log units), on the low side; measured number above the stated range.
By their numbers in this assay, from the lowest: compounds 2 and 3 (each within the scatter of the next); then compounds 1 and 4 (each within the scatter of the next).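

Changing only the ring on the carbonyl matters at this position: 1,3-thiazol-2-yl in place of 1-methyl-1H-pyrazol-5-yl gives a 5.5-fold higher number from compound 2 to compound 4 (0.74 log units; beyond the scatter) and so undoes the gain seen with compound 2. An aromatic ring on a carbonyl therefore does not by itself give a low number, as shown by a 5.2-fold higher number from compound 3 to compound 4 (0.71 log units; beyond the scatter), while a 1.1-fold higher number from compound 1 to compound 4 (0.05 log units; within the scatter) is a step within the scatter. Nothing measured here gives a reason for the difference between the two rings.

Which feature of these two rings separates them stays open, as does how a plain phenyl ring or a 1,3-oxazol-2-yl ring on the same carbonyl would read.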